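A Cyano Group Added to Compound 2

The compounds below may be only part of what the source reports. "The series", "measured", "known", "first", "only" and "open" are said of these compounds alone.

Compound 1 `COc1ccc2c(c1)c(-c1cc(C(F)(F)F)c(C#N)c(-c3cn(S(=O)(=O)c4ccc(C)cc4)c4ccc(OC)cc34)n1)cn2S(=O)(=O)c1ccc(C)cc1`: 25.2%
Compound 2 `Cc1ccc(S(=O)(=O)n2cc(-c3cc(C(F)(F)F)cc(-c4cn(S(=O)(=O)c5ccc(C)cc5)c5cc(Br)ccc45)n3)c3ccc(Br)cc32)cc1`: 32%

Of the compounds shown here, two have been measured in a functional assay on A549 cells (Homo sapiens) for inhibition, tested at 10 uM; a lower number here means a weaker effect, a higher number a stronger effect of the compound at the concentration tested. Compound 2 gives 32% and holds the higher of the two readings, but its gap to compound 1 lies within the usual scatter, so the two cannot be separated on these numbers. Compound 1 gives 25.2% in this assay; it carries a cyano group of its own, yet it also differs from compound 2 at several other places, so its value says nothing direct about the cyano group alone.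

Compound 3 `Cc1ccc(S(=O)(=O)n2cc(-c3cc(C(F)(F)F)c(C#N)c(-c4cn(S(=O)(=O)c5ccc(C)cc5)c5cc(Br)ccc45)n3)c3ccc(Br)cc32)cc1` is the next compound to be tested. It differs from compound 2 in one place: cyano in place of hydrogen on an aromatic carbon. Among the measured compounds shown here, no measured pair in this set isolates this change, so nothing beyond the scatter can be expected with confidence. The step from compound 2 to compound 3 in this assay is therefore expected to be small, a number 2 percentage points lower from compound 2 to compound 3 (within the scatter), in no clear direction. Compound 3 is estimated to give 30%, with a range from 10% to 55%.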

Compound 3, a percentage reported as inhibition, at one concentration (the size of the read-out at that concentration, not a potency): 27.6%
Beside the measured number, compound 3's estimate is 2.4 percentage points above it; the range from low to high includes it.
By their numbers in this assay, from the lowest: compounds 1, 3 and 2 (each within the scatter of the next).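

Among the compounds shown here, this pair is the first in the set to isolate a single change: cyano in place of hydrogen on an aromatic carbon of a six-membered aromatic ring with 1 nitrogen, ortho to a trifluoromethyl group and two atoms from the ring nitrogen. In this assay this change gives a number 4.4 percentage points lower from compound 2 to compound 3 (within the scatter), so at this position, on the shared core of compound 2 and compound 3, the cyano group cannot be told apart from hydrogen, and the position accepts the added group without a reading that can be separated from that of the parent compound. No other measurement available here bears on this result, and the reading itself offers no explanation for it.

This single pair leaves open whether an amine or a carboxylic acid on the same aromatic carbon would move the reading beyond the scatter, or would likewise leave it unchanged. Since each reading comes from one concentration and is not a potency, the compounds shown also leave open whether compound 2 and compound 3 would still be indistinguishable at other concentrations.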